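Swapping methoxy for methylsulfanyl on a chalcone-like scaffold

The source may hold more compounds than are shown below. What is called first, only, known or untested is meant among the compounds shown, and "the series" means these compounds.

Measured so far:
compound 1 `COc1cc(OC)c(C(=O)/C=C/c2ccccc2SC)c(OC)c1`, 35%
compound 2 `COc1cc(O)c(C(=O)/C=C/c2ccccc2OC)c(OC)c1`, 43%
compound 3 `COc1cc(OC)c(C(=O)/C=C/c2ccc(Cl)cc2)c(OC)c1`, 40%

All three were tested in a functional assay on NCI-H727 cells (Homo sapiens), read by fluorescence and BrdU incorporation, with a stated time of 48 h, tested at 10 uM; a lower number here means a stronger effect, a higher number a weaker effect of the compound at the concentration tested. Compound 2 holds the highest of the three numbers, but its nearest neighbour, compound 3, sits only a little lower, and even compound 1, the furthest, lies within the scatter of compound 2, so the three are not separated in any reliable way.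

Compound 4 `COc1cc(O)c(C(=O)/C=C/c2ccccc2SC)c(OC)c1` is the unmeasured compound. It keeps the core of compound 2 and differs only in one spot: methylsulfanyl in place of methoxy on an aromatic carbon.

Among the compounds with values here, only one measured step exists, a number 5 percentage points higher from compound 1 to compound 3 (within the scatter), and it concerns a different exchange on the same aromatic ring, not the methoxy-to-methylsulfanyl swap. That step was within the scatter. Within the data shown here, compound 1 carries the methylsulfanyl group on a different core, with 35%, and compound 2 with its methoxy group gives 43%; these two values are also within the scatter of each other, though they differ in two places and no single step connects them.

The expectation is therefore a step of a number 4 percentage points lower from compound 2 to compound 4 (within the scatter) that does not go beyond the scatter. Compound 4 is estimated at 39%, with a range from 26% to 52%.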

Compound 4, a percentage reported as activity, at one concentration (the size of the read-out at that concentration, not a potency): 43%
Compound 4: middle estimate off by 4 percentage points, on the low side; the measured number falls inside the stated range.
By their numbers in this assay, from the lowest: compounds 1, 3, 2 and 4 (each within the scatter of the next).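

In this assay, within the data shown here, methylsulfanyl in place of methoxy on an aromatic carbon, ortho to a large group, gives no change at the digits printed from compound 2 to compound 4 (within the scatter); this is the first reading of that swap with the rest of the molecule held the same. The second new step, hydrogen in place of methyl on an oxygen on an aromatic ring, gives a number 8 percentage points higher from compound 1 to compound 4 (within the scatter), so with methylsulfanyl in place, this change on the other ring does not separate the two compounds either. Nothing measured alongside these compounds bears on what lies behind these results.

The compounds shown leave open whether any exchange at this aromatic carbon can move the read-out beyond the usual scatter, for example a dimethylamino group, a carboxylic acid or a longer chain such as butylsulfanyl. Because every number here comes from a single concentration, they also leave open whether compound 2 and compound 4 would still show an effect of the same size at other concentrations.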